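Cytotoxicity notes: thiophene in place of methoxyphenyl

The source may report more compounds than this note shows. Statements on the series, on what has been measured and on what is new or still open speak of the compounds shown alone.

Compound 1 `COc1ccc(C2C(C#N)=C(N)N(c3ccc(S(N)(=O)=O)cc3)C3=C2CCCC3)cc1` is the reference point of this small set. In a functional assay on Ehrlich cells (Mus musculus) for cytotoxicity, read by trypan blue exclusion, with a stated time of 2 h, tested at 10 ug/mL (on this read-out lower numbers stand for a weaker effect and higher numbers for a stronger effect at the one concentration tested), compound 1 gives 50%, the highest of the three numbers measured. Compound 2 `COc1ccc2ccccc2c1C1C(C#N)=C(N)N(c2ccc(S(N)(=O)=O)cc2)C2=C1CCCC2`, which carries a methoxynaphthyl group, gives 5% in this assay, and compound 3 `COc1ccc(C2C(C#N)=C(N)N(c3ccc(S(N)(=O)=O)cc3)C3=C2CCCC3)c2ccccc12`, carrying the other methoxynaphthyl arrangement, gives 0%. Both lie below compound 1 by more than the usual scatter, so compound 1 is the strongest of the three on this read-out.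

Compound 4 `N#CC1=C(N)N(c2ccc(S(N)(=O)=O)cc2)C2=C(CCCC2)C1c1cccs1` has not yet been measured. It differs from compound 1 in one place: thiophen-2-yl in place of 4-methoxyphenyl on a saturated ring carbon. For the measured compounds named here, no measured pair in the set shows a change of this kind, so the expectation rests only on the shared core and on the fact that the two larger aromatic groups give low numbers: compound 2 gives 5% and compound 3 gives 0%. The step from compound 1 to compound 4 is expected to be a modest fall, about a number 12 percentage points lower from compound 1 to compound 4 (beyond the scatter), not clearly beyond the scatter. Compound 4 is estimated to give 38% in this assay, within a range from 12% to 65%.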

Compound 4, a percentage reported as activity, at one concentration (the size of the read-out at that concentration, not a potency): 0%
For compound 4 the middle estimate is 38 percentage points above the measured one; measured number outside the range, below it.
By their numbers in this assay, from the lowest: compounds 3, 4 and 2 (each within the scatter of the next); then compound 1.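

For the compounds shown here, the pair gives the first step that can be read in one place: in this assay the change to thiophen-2-yl in place of 4-methoxyphenyl on a saturated ring carbon gives a number 50 percentage points lower from compound 1 to compound 4 (beyond the scatter) and leaves the rest of the core of compound 1 unchanged. The read-out therefore depends strongly on the group at this carbon, and a five-membered aromatic ring with 1 hetero atom does not keep the effect of compound 1. No measurement at hand accounts for the size of this step.

Still open, going by these compounds, is whether the effect of compound 1 rests on the methoxy group or on the six-membered aromatic ring of carbon only. Plain phenyl, 4-hydroxyphenyl or 4-chlorophenyl on this carbon would separate the two.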